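A few compounds are considered here, and "the series" means these few. Any claim that something is new, unique, unknown or untested is made for them only; others in the source may bear on it.

Measured compounds and their numbers in a functional assay on HeLa cells (Homo sapiens) for cytotoxicity, read by MTT assay; a lower number here means a stronger inhibitor, a higher number a weaker inhibitor:
compound 1 `CCCCC(O)CC(=O)O[C@H](CC=C(C)C)C1=CC(=O)c2c(O)ccc(O)c2C1=O`, for which compound 1 gives 72200 nM
compound 2 `CC[C@@](C)(O)CC(=O)O[C@H](CC=C(C)C)C1=CC(=O)c2c(O)ccc(O)c2C1=O`, for which compound 2 gives 17900 nM
compound 3 `CC[C@](C)(O)CC(=O)O[C@H](CC=C(C)C)C1=CC(=O)c2c(O)ccc(O)c2C1=O`, for which compound 3 gives 30200 nM

Compound 3 stands second highest of the three; its nearest neighbour is compound 2, within the scatter, and compound 1 lies furthest from it, beyond the scatter. The measured steps alter only the acyl chain of the ester: a 4.0-fold lower number from compound 1 to compound 2 (0.61 log units; beyond the scatter) and a 2.4-fold lower number from compound 1 to compound 3 (0.38 log units; beyond the scatter), both modest, while a 1.7-fold higher number from compound 2 to compound 3 (0.23 log units; within the scatter) stays within the scatter, consistent with the fact that compounds 2 and 3 differ only in the configuration as drawn.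

Compound 4 `CC(=O)OC(C)CO[C@H](CC=C(C)C)C1=CC(=O)c2c(O)ccc(O)c2C1=O` differs from compound 3 at the ester oxygen: 2-acetoxypropyl in place of (2-hydroxy-2-methylbutyl)carbonyl on an oxygen on a saturated carbon. Among the compounds with values here, no measured step touches this position directly, so the acyl-chain steps serve only as a rough guide; the step of a 1.0-fold lower number from compound 3 to compound 4 (0.00 log units; within the scatter) is expected to be small in either direction. Compound 4 is estimated at 30000 nM, within 10000 nM to 100000 nM.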

Compound 4, half-maximal inhibitory concentration: 40100 nM
Compound 4: middle estimate off by 1.3-fold (0.13 log units), on the low side; the range from low to high includes it.
By their numbers in this assay, from the lowest: compounds 2, 3, 4 and 1 (each within the scatter of the next, the first and the last beyond it).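

In this assay the oxygen on a saturated carbon carries 2-acetoxypropyl about as well as an acyl chain: a 1.3-fold higher number from compound 3 to compound 4 (0.12 log units; within the scatter) and a 1.8-fold lower number from compound 1 to compound 4 (0.26 log units; within the scatter) both stay within the scatter, and only a 2.2-fold higher number from compound 2 to compound 4 (0.35 log units; beyond the scatter) goes beyond it, as a modest step. The entering group has 0 hydrogen-bond donors against 1 in (2-hydroxy-2-methylbutyl)carbonyl, so that donor is not needed to keep the number in this range. Nothing on hand bears on the reason for this result.

Open, from the compounds shown here alone, is whether an amine, a carboxylic acid or a longer chain on this oxygen would shift the number beyond the scatter.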